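Trimming an amide in a fused core series

The source may hold more compounds than are shown below. What is called first, only, known or untested is meant among the compounds shown, and "the series" means these compounds.

Compound 2 `COC(=O)N1CCN([C@H]2CC[C@H](Nc3ncnn4ccc([C@H](C)CC(=O)N(C)C)c34)CC2)CC1` has the higher of the two values recorded in a physicochemical assay for lipophilicity, using the shake flask method, at pH 7.4 (on this read-out lower numbers stand for lower lipophilicity and higher numbers for higher lipophilicity), where compound 2 gives 2.3. Compound 1 `CC(=O)N1CCN([C@H]2CC[C@H](Nc3ncnn4ccc([C@H]5CC[C@H](C(N)=O)CC5)c34)CC2)CC1` sits a full step lower, beyond the usual scatter, and in this assay compound 1 gives 1.4. Compound 3 `COC(=O)N1CCN([C@H]2CC[C@H](Nc3ncnn4ccc([C@H](C)CC(N)=O)c34)CC2)CC1` has not yet been measured. It differs from compound 2 in one place: amino in place of dimethylamino on a carbonyl carbon. Going by the values given here, no measured pair shows this change, so compound 3 is expected to move downward by a number 0.80 log units lower from compound 2 to compound 3 (beyond the scatter). In this assay compound 3 is therefore estimated at 1.5, within a range from 1 to 2.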

Compound 3, distribution coefficient: 1.9
Compound 3: middle estimate off by 0.40 log units, on the low side; the range from low to high includes it.
By their numbers in this assay, from the lowest: compound 1; then compound 3; then compound 2.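

In this assay, the change from dimethylamino to amino on a carbonyl carbon now has a measured size: a number 0.40 log units lower from compound 2 to compound 3 (beyond the scatter). This single pair shows that the read-out registers the change at this position, with the saturated chain carbon and the rest of the molecule unchanged, but it establishes no pattern. Nothing available bears on why the step has this size. The compounds shown leave open how a methylamino group or a carboxylic acid on this carbonyl carbon would read in this assay. They also leave open whether the same step would appear on a longer chain.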